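The source may report more compounds than this note shows. Statements on the series, on what has been measured and on what is new or still open speak of the compounds shown alone.

Measured so far:
Compound 1 `COc1ccc(OCCOCCNC2CCCC2)cc1`: 99100 nM
Compound 2 `Clc1ccc(COc2ccc(OCCOCCNC3CCCC3)cc2)cc1`: 7670 nM
Compound 3 `Nc1ccccc1COc1ccc(OCCOCCNC2CCCC2)cc1`: 14000 nM

In a functional assay on SK-OV-3 cells (Homo sapiens) for inhibition, read by CCK-8 assay, with a stated time of 70 h (a lower number here means a stronger inhibitor, a higher number a weaker inhibitor), compound 2 gives 7670 nM and shares the low end of the range with compound 3, as a 1.8-fold higher number from compound 2 to compound 3 (0.26 log units; within the scatter) shows. Both lie well clear of compound 1, with a 13-fold lower number from compound 1 to compound 2 (1.11 log units; beyond the scatter) and a 7.1-fold lower number from compound 1 to compound 3 (0.85 log units; beyond the scatter).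

The next compound, compound 4 `c1ccc(COc2ccc(COc3ccc(OCCOCCNC4CCCC4)cc3)cc2)cc1`, keeps the rest of compound 2 but carries benzyloxy in place of chloro on an aromatic carbon, para to a large group: benzyloxy in place of chloro on an aromatic carbon. For the measured compounds named here, no measured compound carries benzyloxy, so there is no direct precedent. The closest guide is a 1.8-fold higher number from compound 2 to compound 3 (0.26 log units; within the scatter), a swap of one substituted aryl group for another that stayed small. The two larger steps each replaced a hydrogen, which is a different kind of change. A small step in this assay is therefore expected, perhaps slightly downward but not clearly beyond the scatter. The estimated step is a 1.4-fold lower number from compound 2 to compound 4 (0.14 log units; within the scatter). The expected value for compound 4 is 5500 nM, with an estimated range of 2000 nM to 14000 nM.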

Compound 4, half-maximal inhibitory concentration: 10000 nM
For compound 4 the middle estimate is 1.8-fold (0.26 log units) below the measured one; measured number inside the range.
By their numbers in this assay, from the lowest: compounds 2, 4 and 3 (each within the scatter of the next); then compound 1.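

For the compounds shown here, compound 4 is the first change made on the outer aromatic ring itself rather than a swap of the whole aryl group, and it shows that this carbon, para to a large group, can carry far more than chloro: benzyloxy brings 8 heavy atoms and a further six-membered aromatic ring, yet this assay gives a 1.3-fold higher number from compound 2 to compound 4 (0.12 log units; within the scatter). Within this assay, then, chloro and benzyloxy at this position cannot be told apart, despite the large difference in size. No measurement at hand accounts for this.

The compounds shown leave open how an amine or a carboxylic acid would read at this same carbon. They also leave open whether a longer chain between the oxygen and the terminal phenyl ring would keep the number in this range.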